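A few compounds are considered here, and "the series" means these few. Any claim that something is new, unique, unknown or untested is made for them only; others in the source may bear on it.

The measured compounds in a functional assay on PC-3 cells (Homo sapiens) for cytotoxicity, read by MTT assay, with a stated time of 72 h; on this read-out higher numbers stand for weaker inhibition of growth and lower numbers for stronger inhibition of growth:
Compound 1, `Sc1ccnc(S)n1`, gives > 100000 nM, which is a limit of the assay rather than a number.
Compound 2, `O=C1c2ccccc2C(=O)N1CS`, gives > 100000 nM, likewise a limit rather than a number.

Compound 2 therefore stands at the limit of > 100000 nM in this assay, at which 2 of the 2 values shown sit. Among the measured compounds shown here, since both values shown are limits, no step between measured compounds can be sized here. Compound 3, `N#C[Se]CN1C(=O)c2ccccc2C1=O`, differs from compound 2 by a group of 3 heavy atoms (1 carbon, 1 nitrogen, 1 selenium; no ring) in place of one sulfur atom, on a saturated chain carbon bound to an amide-type nitrogen in a ring. With nothing measured to go by, a move toward stronger growth inhibition is expected, and the step from compound 2 to compound 3 is estimated at an at least 5.0-fold lower number from compound 2 to compound 3 (0.69 log units; beyond the scatter). Compound 3 is expected to give about 20000 nM, within a range from 3000 nM to 100000 nM, though a limit again remains possible.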

Compound 3, concentration for total growth inhibition: 32100 nM
Beside the measured number, compound 3's estimate is 1.6-fold (0.21 log units) below it; the range from low to high includes it.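

Among the compounds shown here, this is the first sign that the place on a saturated chain carbon bound to an amide-type nitrogen in a ring responds in this assay: replacing sulfanyl with the group of selenium, carbon and nitrogen gives an at least 3.1-fold lower number from compound 2 to compound 3 (0.49 log units; beyond the scatter). The true size of that step remains unknown, since compound 2 gives a limit of the assay rather than a number: the limit of > 100000 nM in this assay, at which 2 of the 3 values shown sit.

Going by these compounds, whether the selenium or the triple bond matters stays open, and a thiocyanate, with sulfur in place of selenium, would separate the two. On these data alone, what an amine or a longer chain would give at this place is also open.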